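Chloro to hydroxy on the phenyl of the carbonyl: compound 4

The compounds below may be only part of what the source reports. "The series", "measured", "known", "first", "only" and "open" are said of these compounds alone.

The series shares one core, varied only on the phenyl attached to the carbonyl. Compound 1 `COc1cc(-c2nnc3n2NC(c2ccco2)C(C(=O)c2ccc(C)cc2)S3)cc(OC)c1OC` is read in a functional assay on A549 cells (Homo sapiens) for cytotoxicity, read by MTT assay, with a stated time of 48 h; a lower number here means a stronger inhibitor, a higher number a weaker inhibitor; for compound 1 the result is a limit of the assay, > 100000 nM, and one of the three values sits at that limit (the limit of > 100000 nM in this assay, at which 1 of the 3 values shown sits). Compound 2 `COc1cc(-c2nnc3n2NC(c2ccco2)C(C(=O)c2ccccc2C)S3)cc(OC)c1OC` gives 80000 nM in this assay, and compound 3 `COc1cc(-c2nnc3n2NC(c2ccco2)C(C(=O)c2ccc(Cl)cc2)S3)cc(OC)c1OC` gives 51400 nM. The steps are small: an at least 1.2-fold lower number from compound 1 to compound 2 (0.09 log units; that floor lies within the scatter), an at least 1.9-fold lower number from compound 1 to compound 3 (0.28 log units; that floor lies within the scatter) and a 1.6-fold lower number from compound 2 to compound 3 (0.19 log units; within the scatter). Compound 3 thus holds the lowest of the two numbers, with compound 2 nearest and within the scatter, so no ordering between them is claimed.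

Compound 4 `COc1cc(-c2nnc3n2NC(c2ccco2)C(C(=O)c2ccc(O)cc2)S3)cc(OC)c1OC` differs from compound 3 by hydroxy in place of chloro on an aromatic carbon. Among the compounds with values here, the steps that bear on this position are those of compound 1 to compound 3 and compound 2 to compound 3, both changes of the substituent on the same phenyl, and neither exceeds the scatter. A step in this assay beyond the scatter is therefore not expected in either direction for compound 4. The expected step is a 1.2-fold higher number from compound 3 to compound 4 (0.07 log units; within the scatter). Compound 4 is estimated at 60000 nM, between 20000 nM and 150000 nM, with a real chance that only a limit is reported.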

Compound 4, half-maximal inhibitory concentration: 93400 nM
Compound 4: the middle estimate sits 1.6-fold (0.19 log units) below what was measured; the measured number falls inside the stated range.
By their numbers in this assay, from the lowest: compounds 3, 2 and 4 (each within the scatter of the next). At a limit, above all of these: compound 1.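

Hydroxy enters on the aromatic carbon para to a large group with a hydrogen-bond donor and acceptor where chloro has none, and in this assay this exchange on the phenyl of the carbonyl gives no step beyond the scatter: a 1.8-fold higher number from compound 3 to compound 4 (0.26 log units; within the scatter). The comparison with the 2-methylphenyl group also stays within the scatter, a 1.2-fold higher number from compound 2 to compound 4 (0.07 log units; within the scatter), so compound 2, compound 3 and compound 4 carry no order among them, and this position has so far given no measurable separation between those three groups. Against 4-methylphenyl only a floor can be read, an at least 1.0-fold lower number from compound 1 to compound 4 (0.02 log units; that floor lies within the scatter), since that value is a limit and not a number: the limit of > 100000 nM in this assay, at which 1 of the 4 values shown sits.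

The compounds shown leave open whether any group on this phenyl gives a step beyond the scatter, for instance an amine or a carboxylic acid in the place now held by hydroxy. Also open, from the compounds shown here alone, is whether a longer chain in place of methyl, or a nitrile in place of chloro, would separate from the values seen here.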